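Methoxy Addition on a Bicyclic Ether Core: Expected Cytotoxicity

The compounds below may be only part of what the source reports. "The series", "measured", "known", "first", "only" and "open" are said of these compounds alone.

Compound 1 `COc1cccc([C@H]2CC(C)(O)[C@@H]3CC[C@@H](C)C[C@H]3O2)c1OC` carries two methoxy groups on its aromatic ring and a hydroxyl on the core. In an ADME assay on MDCK cells (Canis lupus familiaris) for cytotoxicity, read by MTT assay, with a stated time of 48 h (on this read-out lower numbers stand for higher toxicity in this test and higher numbers for lower toxicity in this test), compound 1 gives > 937000 nM, which is a limit of the assay and not a number. Compound 2 `COc1ccc([C@H]2CC(C)(O)[C@@H]3CC[C@@H](C)C[C@H]3O2)c(OC)c1OC` adds a third methoxy, (methoxy in place of hydrogen on an aromatic carbon). In this assay compound 2 gives > 857000 nM, again a limit rather than a number. The step that the two limits leave unreadable from compound 1 to compound 2 therefore cannot be read, as both values are limits the limit of > 857000 nM in this assay, at which 1 of the 3 values shown sits (the limit of > 937000 nM in this assay, at which 1 of the 3 values shown sits).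

Among the measured compounds shown here, compound 3 `C[C@@H]1CC[C@@H]2[C@@H](C1)O[C@@H](c1ccccc1)CC2(C)F` replaces the hydroxyl with fluorine and bears an unsubstituted aromatic ring; in this assay compound 3 gives 65000 nM, the only number among the three. The difference between the cores of compound 1 and compound 3 is not broken down here.

Compound 4 `COc1ccc([C@H]2CC(C)(F)[C@@H]3CC[C@@H](C)C[C@H]3O2)cc1` has not been measured. It differs from compound 3 by methoxy in place of hydrogen on an aromatic carbon. This is the same kind of change as that from compound 1 to compound 2, but the surroundings differ: in compound 2 the entering methoxy is ortho to a methoxy group and meta to a methoxy group as well as para to a large group, whereas in compound 4 it is only para to a large group.

Because the step that the two limits leave unreadable from compound 1 to compound 2 is unreadable and compound 3 gives 65000 nM, the step of a 1.4-fold higher number from compound 3 to compound 4 (0.14 log units; within the scatter) is expected to be small. Compound 4 is thus estimated at 90000 nM, within 30000 nM to 300000 nM.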

Compound 4, half-maximal cytotoxic concentration: 171000 nM
Beside the measured number, compound 4's estimate is 1.9-fold (0.28 log units) below it; measured number inside the range.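

In this assay, methoxy in place of hydrogen on an aromatic carbon, para to a large group, gives a 2.6-fold higher number from compound 3 to compound 4 (0.42 log units; beyond the scatter), so on the fluorine-bearing core the change has a readable size, and that size is modest. Among the compounds shown here, on the hydroxyl-bearing core, the same kind of change from compound 1 to compound 2 cannot be read, and compound 2 stands at a limit of the assay, not a number: the limit of > 857000 nM in this assay, at which 1 of the 4 values shown sits. The single readable step therefore shows what this change does on one core and in one setting on the aromatic ring, but it does not show that the change carries over to the other core in either size or direction, and the two cores offer no pair of steps to set side by side.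

From the compounds shown here alone, whether the higher number seen with methoxy would also appear with an amine or a carboxylic acid in the same place, or with a longer chain such as ethoxy, remains open. Also open is how hydroxyl and fluorine compare on compounds that match in every other respect, since the compounds shown offer no such pair.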